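Aminomethyl for amino on the aryl ester series

The source may hold more compounds than are shown below. What is called first, only, known or untested is meant among the compounds shown, and "the series" means these compounds.

Compound 3 `N=C(N)Nc1ccc(C(=O)Oc2ccc(N)cc2)cc1` gives 103% in an assay on isolated protein for inhibition of Trypsin (Homo sapiens), read by fluorescence, with a stated time of 15 min, tested at 50 uM (on this read-out higher numbers stand for more inhibition at the one concentration tested (going by the name of the read-out) and lower numbers for less inhibition), the highest of the three numbers shown. Compound 1 `N=C(N)Nc1ccc(OC(=O)c2ccc(NC(=N)N)cc2)cc1` gives 100% in this assay , and the step of a number 3 percentage points higher from compound 1 to compound 3 (within the scatter) shows that removing a guanidine-type group on an aromatic nitrogen made no difference beyond the scatter. Among the compounds with values here, compound 2 `N=C(N)NCCCOC(=O)c1ccc(NC(=N)N)cc1` gives 78.9% in this assay ; its two values with compound 3 show that the propyl-chain ester sits well below the aryl esters, beyond the scatter, though no single-place step joins them.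

Compound 4 `N=C(N)Nc1ccc(C(=O)Oc2ccc(CN)cc2)cc1` differs from compound 3 by aminomethyl in place of amino on an aromatic carbon, the change sitting on an aromatic carbon of a six-membered aromatic ring of carbon only, para to a large group. Within the data shown here, no measured step changes this position, so the only guide is that compound 3 and compound 1 both give numbers near the top of the range seen here and that the one alteration on the amine side of compound 3 left the number within scatter. With a saturated carbon inserted between the ring and the amine, a step of a number 8 percentage points lower from compound 3 to compound 4 (within the scatter) is expected, small and most likely within the scatter, with some room downward. Compound 4 is therefore estimated at 95% in this assay , between 78% and 105%.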

Compound 4, a percentage reported as inhibition, at one concentration (the size of the read-out at that concentration, not a potency): 101%
Compound 4: middle estimate off by 6 percentage points, on the low side; measured number inside the range.
By their numbers in this assay, from the lowest: compound 2; then compounds 1, 4 and 3 (each within the scatter of the next).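

In this assay, aminomethyl in place of amino on this aromatic carbon, para to a large group, gives a number 2 percentage points lower from compound 3 to compound 4 (within the scatter), so at this place the added saturated carbon leaves the number within the scatter. Against the larger guanidine-type group of compound 1, the same aminomethyl gives a number 1 percentage points higher from compound 1 to compound 4 (within the scatter), so three different groups at this place now give numbers that cannot be told apart in this read-out. No measurement offered here explains why the number holds across these groups.

Still open, from the compounds shown here alone, is whether any group at this place lowers the number beyond the scatter: a carboxylic acid, a longer chain such as aminoethyl, or a plain hydrogen would each test that. Also open, going by these compounds, is any order of potency among compound 1, compound 3 and compound 4, as a reading at one concentration gives the size of the inhibition and not a potency, and a full concentration series could separate what this single reading cannot.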